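The source may report more compounds than this note shows. Statements on the series, on what has been measured and on what is new or still open speak of the compounds shown alone.

Measured so far in a functional assay on CCRF-CEM cells (Homo sapiens) for antiproliferative activity, read by cell counting, with a stated time of 2 days; on this read-out higher numbers stand for weaker inhibition and lower numbers for stronger inhibition:
compound 1 `COc1cc(C(=O)c2sc(Nc3ccc(C)cc3)nc2N)cc(OC)c1OC`, 41 nM
compound 2 `COc1ccc(C(=O)c2sc(Nc3ccc(Cl)cc3)nc2N)cc1`, > 10000 nM
compound 3 `COc1ccc(Nc2nc(N)c(C(=O)c3ccc(Br)cc3)s2)cc1`, 39 nM

Compound 1 gives the higher of the two numbers in this assay, but compound 3 sits so close that the two lie within the scatter and no order between them can be read. The value of compound 2 is a limit, not a number, and it is the one case where (the limit of > 10000 nM in this assay, at which 1 of the 3 values shown sits). For the measured compounds named here, compound 2 and compound 3 each differ from compound 1 in more than one place, so no single step between measured compounds is available, and the series gives no direct measure of what a change at the position in question does.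

Compound 4 `COc1cc(C(=O)c2sc(Nc3ccc(F)cc3)nc2N)cc(OC)c1OC` is the next compound to be measured. It differs from compound 1 in one place: fluoro in place of methyl on an aromatic carbon. Going by the values given here, with no measured step of this kind to lean on, the expectation rests on compound 1 and compound 3 giving values within the scatter of each other despite differing in more than one place, which suggests the series tolerates changes of this sort. A step of a 1.3-fold higher number from compound 1 to compound 4 (0.13 log units; within the scatter) is expected, small and most likely not beyond the scatter. For compound 4 in this assay the estimate is 55 nM, with a range from 15 nM to 250 nM.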

Compound 4, half-maximal inhibitory concentration: 400 nM
Compound 4: middle estimate off by 7.3-fold (0.86 log units), on the low side; the whole stated range lies below it.
By their numbers in this assay, from the lowest: compounds 3 and 1 (each within the scatter of the next); then compound 4. At a limit, above all of these: compound 2.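

In this assay, for the compounds shown here, the exchange of 4-methylphenyl for 4-fluorophenyl gives the first reading of a change in one place, a 9.8-fold higher number from compound 1 to compound 4 (0.99 log units; beyond the scatter) on the core of compound 1. The position on the aromatic carbon para to a large group is therefore not indifferent to the group it carries, even though the change replaces a single heavy atom with a single heavy atom and the hydrogen-bond donor and acceptor counts stay the same. On this core, the methyl of compound 1 gives the lower number of the two, but this single pair gives the size of one step only and sets no trend for the position.

Methyl and fluoro are the only groups read at this position on the core of compound 1, so it remains open where an ethyl, a trifluoromethyl or an amine in the same place would fall in this assay and whether any of them would match methyl. The measurements shown hold nothing that bears on the cause of this step.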